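The source may hold more compounds than are shown below. What is called first, only, known or untested is meant among the compounds shown, and "the series" means these compounds.

In an ADME assay on MT2 cells (Homo sapiens) for cytotoxicity, read by MTT assay (on this read-out lower numbers stand for higher toxicity in this test and higher numbers for lower toxicity in this test), compound 1 `N#Cc1ccc2c(Oc3ccc(F)cc3OCCn3ccc(=O)[nH]c3=O)cc(Cl)cc2c1` gives 16000 nM. Compound 2 `N#Cc1ccc2c(Oc3ccc(Cl)cc3OCCn3ccc(=O)[nH]c3=O)cccc2c1` reaches only the limit of this assay, > 100000 nM. Compound 3 `N#Cc1ccc2c(Oc3ccc(F)cc3OCCn3ccc(=O)[nH]c3=O)cc(F)cc2c1` likewise sits at the limit, > 100000 nM. The step of an at least 6.2-fold higher number from compound 1 to compound 3 (0.79 log units; beyond the scatter) is therefore known only as a bound, because of the limit of > 100000 nM in this assay, at which 2 of the 3 values shown sit. Compound 3 thus stands at the high end of the numbers shown, with compound 2 at the same limit and compound 1 alone giving a number. Compound 4 `N#Cc1ccc2c(Oc3ccc(F)cc3OCCn3ccc(=O)[nH]c3=O)cccc2c1` differs from compound 3 by hydrogen in place of fluoro on an aromatic carbon. Going by the values given here, no measured step covers this change; the nearest comparison is compound 2, in which the same carbon bears hydrogen and which sits at the limit. Compound 4 is therefore expected to show no step beyond the scatter, a number no higher from compound 3 to compound 4 (the limit leaves the size open). The value expected for compound 4 in this assay is 100000 nM, from 30000 nM to 300000 nM.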

Compound 4, half-maximal cytotoxic concentration: > 100000 nM
Compound 4 was reported as a limit (the forecaster's own chance of this, stated with the estimate: 70%); the middle value lies on the limit itself.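

In this assay, hydrogen on this aromatic carbon leaves the compound at a limit, as fluoro did, and the step from chloro is (an at least 6.2-fold higher number from compound 1 to compound 4 (0.79 log units; beyond the scatter)). Of chloro, fluoro and hydrogen at this place, only chloro, in compound 1, gives a number rather than a limit. The steps among compound 2, compound 3 and compound 4 cannot be read, because each of these compounds gives only a limit: the limit of > 100000 nM in this assay, at which 3 of the 4 values shown sit.

On these data alone, how far hydrogen and fluoro lie apart here stays open. Also open, as far as these compounds go, is what bromo, methoxy or an amine on this carbon would give in this assay.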